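Isopropyl on the Sulfonamide Nitrogen of the Bromo Analogue

A few compounds are considered here, and "the series" means these few. Any claim that something is new, unique, unknown or untested is made for them only; others in the source may bear on it.

Measured compounds, with their values in a functional assay on the whole organism (strain STD-dd) with Mus musculus as the target, in the maximal electroshock model, with a stated time of 2 h; on this read-out lower numbers stand for an effect already at smaller amounts and higher numbers for an effect only at larger amounts of compound:
- compound 1, `NS(=O)(=O)Cc1noc2ccc(Cl)cc12`: 14 mg/kg
- compound 2, `CC(C)NS(=O)(=O)Cc1noc2ccc(Cl)cc12`: 100 mg/kg
- compound 3, `NS(=O)(=O)Cc1noc2ccc(Br)cc12`: 14 mg/kg

Compound 3 gives 14 mg/kg in this assay and stands level with compound 1; together they carry the lowest numbers of the three. The two steps that place it read no change at the digits printed from compound 1 to compound 3 (within the scatter) and a 7.1-fold higher number from compound 1 to compound 2 (0.85 log units; beyond the scatter), so the bromo-for-chloro swap left the number untouched while the isopropyl on the chloro compound moved it well beyond the scatter.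

Compound 4, `CC(C)NS(=O)(=O)Cc1noc2ccc(Br)cc12`, differs from compound 3 in one place: isopropyl in place of hydrogen on a sulfonamide nitrogen. For the measured compounds named here, only one measured step bears on this change, and it is the same substitution on the chloro analogue, a 7.1-fold higher number from compound 1 to compound 2 (0.85 log units; beyond the scatter). Because the halogen swap itself gave no change at the digits printed from compound 1 to compound 3 (within the scatter), there is no sign so far that the bromo core answers differently from the chloro core, so the same modest rise is the expectation here; a step of a 7.1-fold higher number from compound 3 to compound 4 (0.85 log units; beyond the scatter) is expected, in the direction of a larger dose. On that basis compound 4 is expected to give about 100 mg/kg in this assay, with a range from 50 mg/kg to 200 mg/kg.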

Compound 4, dose for half-maximal effect: 22 mg/kg
For compound 4 the middle estimate is 4.5-fold (0.66 log units) above the measured one; measured number below the stated range.
By their numbers in this assay, from the lowest: compounds 1, 3 and 4 (each within the scatter of the next); then compound 2.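

In this assay, isopropyl in place of hydrogen on the sulfonamide nitrogen of the bromo compound gives a 1.6-fold higher number from compound 3 to compound 4 (0.20 log units; within the scatter), so the change that separated the chloro pair does not separate this pair: the same change on two cores in this assay, a 7.1-fold higher number (0.85 log units; beyond the scatter) from compound 1 to compound 2 and a 1.6-fold higher number (0.20 log units; within the scatter) from compound 3 to compound 4, 4.5-fold (0.66 log units) apart, beyond the scatter of two such steps. The swap of bromo for chloro on the aromatic carbon, which left the number untouched with hydrogen on the sulfonamide nitrogen, gives a 4.5-fold lower number from compound 2 to compound 4 (0.66 log units; beyond the scatter) with isopropyl there: the same change on two cores in this assay, no change at the digits printed (within the scatter) from compound 1 to compound 3 and a 4.5-fold lower number (0.66 log units; beyond the scatter) from compound 2 to compound 4, 4.5-fold (0.66 log units) apart, beyond the scatter of two such steps. The two places therefore do not act independently in these four compounds, and the outcome of the isopropyl change depends on which halogen the shared core carries.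

Going by these compounds, this interaction rests on a single set of four compounds, and it remains open whether a methyl group or a longer chain such as n-butyl on the sulfonamide nitrogen would follow the chloro pair or the bromo pair. On these data alone, it is also open how fluoro or iodo on the same aromatic carbon would respond to isopropyl on that nitrogen.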